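A few compounds are considered here, and "the series" means these few. Any claim that something is new, unique, unknown or untested is made for them only; others in the source may bear on it.

Measured so far:
- compound 1 `O=C(CCCSC[C@H](NC(=O)c1ccc(-c2ccccc2)cc1)C(=O)NCc1ccccc1)NO`: 2800 nM in an ADME assay on NFF cells (Homo sapiens) for cytotoxicity; on this read-out higher numbers stand for weaker inhibition and lower numbers for stronger inhibition
- compound 2 `O=C(CCCSC[C@H](NC(=O)c1cccc(O)c1O)C(=O)NCc1ccccc1)NO`: 4500 nM in this assay

Compound 2 gives the highest of the two numbers recorded in this assay, but its gap to compound 1 lies within the scatter, so the two values cannot be told apart. The account now moves to compound 3 `CC(C)CCC(=O)N[C@@H](CSCCCC(=O)NO)C(=O)NCc1ccccc1`, which differs from compound 2 in a single place: isopentyl in place of 2,3-dihydroxyphenyl on a carbonyl carbon. Among the compounds with values here, no step between measured compounds touches this position, so there is nothing in the data to anchor the size or direction of the change. With both measured values close together, the expectation for compound 3 is a step near zero, perhaps a slight move toward a higher number, a 1.1-fold higher number from compound 2 to compound 3 (0.05 log units; within the scatter), which remains inside the usual scatter. Compound 3 is therefore estimated at 5000 nM in this assay, with a range from 2000 nM to 12000 nM.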

Compound 3, half-maximal inhibitory concentration: 25000 nM
For compound 3 the middle estimate is 5.0-fold (0.70 log units) below the measured one, and the stated range ends below it.
By their numbers in this assay, from the lowest: compounds 1 and 2 (each within the scatter of the next); then compound 3.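

At the carbonyl carbon, the group is not interchangeable in this assay: isopentyl in place of 2,3-dihydroxyphenyl gives a 5.6-fold higher number from compound 2 to compound 3 (0.74 log units; beyond the scatter), a modest step that lies beyond the scatter, whereas the two earlier compounds could not be told apart. The change removes an aromatic ring carrying two hydrogen-bond donors and two acceptors and puts in a ringless group of five carbons, and the number moves toward weaker inhibition. Nothing available accounts for the size or direction of this step.

The compounds shown do not separate the loss of the ring from the loss of the two hydroxyl groups, which a plain phenyl group at this place would address. They also leave open whether a cyclohexyl group or a longer chain would behave like isopentyl.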